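Trading sulfur for oxygen: compound 2 to compound 3

The source may hold more compounds than are shown below. What is called first, only, known or untested is meant among the compounds shown, and "the series" means these compounds.

In an ADME assay on microsomes from liver (Homo sapiens) for metabolic stability, read by LC-MS, with a stated time of 30 min, tested at 1 uM (a higher number here means that more of the compound is left, a lower number that less of the compound is left), compound 1 (`O=C(NCc1ccc(S(=O)(=O)c2ccccc2)cc1)c1nc2cnccc2[nH]1`) gives 73% and compound 2 (`O=C(NCc1ccc(S(=O)(=O)N2CCCCC2)cc1)c1cc2cnccc2s1`) gives 15% as the lower of the two numbers, a gap beyond the scatter. Compound 3 (`O=C(NCc1ccc(S(=O)(=O)N2CCCCC2)cc1)c1cc2cnccc2o1`) is not yet measured and differs from compound 2 by a group of 9 heavy atoms (7 carbon, 1 nitrogen, 1 oxygen; one five-membered aromatic ring with 1 hetero atom, one six-membered aromatic ring with 1 hetero atom) in place of a group of 9 heavy atoms (7 carbon, 1 nitrogen, 1 sulfur; one five-membered aromatic ring with 1 hetero atom, one six-membered aromatic ring with 1 hetero atom), on a carbonyl carbon on a carbonyl carbon. Among the measured compounds shown here, no measured pair shows this change, so no move beyond the scatter is expected, and the estimated step is a number 5 percentage points higher from compound 2 to compound 3 (within the scatter) in a slightly upward direction. Compound 3 is estimated at 20% within a range from 8% to 40% in this read-out.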

Compound 3, percent of the compound remaining: 46%
For compound 3 the middle estimate is 26 percentage points below the measured one; the whole stated range lies below it.
By their numbers in this assay, from the lowest: compound 2; then compound 3; then compound 1.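

In this assay, the group on the carbonyl carbon carries real weight: oxygen in place of sulfur in the five-membered aromatic ring gives a number 31 percentage points higher from compound 2 to compound 3 (beyond the scatter) with the rest of the molecule unchanged. The two groups match in heavy-atom count, ring types, hydrogen-bond donors and acceptors, and net charge, so none of these counts separates them. No measured evidence on hand explains the step. Open, as far as these compounds go, are whether the step holds in another matched pair and how a group carrying an amine on the carbonyl carbon would compare.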